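Dropping One Bromine From an Inactive Amide

The source may report more compounds than this note shows. Statements on the series, on what has been measured and on what is new or still open speak of the compounds shown alone.

compound 1: `O=C(Nc1cccc(Cl)c1)c1cc(Br)cc(Br)c1O` — 29000 nM
compound 2: `O=C(Nc1ccc(Sc2nc3ccccc3s2)c(Cl)c1)c1cc(Br)cc(Br)c1` — > 100000 nM
compound 3: `O=C(Nc1ccc(Sc2nc3ccccc3s2)cc1)c1cc(Br)cc(Br)c1` — > 100000 nM

In an assay for inhibition of HSP60/HSP10 (Homo sapiens), with a stated time of 60 min (on this read-out lower numbers stand for stronger inhibition and higher numbers for weaker inhibition), compound 1 gives 29000 nM. Compound 2 reaches only a limit of this assay, > 100000 nM. Compound 3 likewise reaches only a limit, > 100000 nM. The change a step that the two limits leave unreadable from compound 2 to compound 3 cannot be sized because the limit of > 100000 nM in this assay, at which 2 of the 3 values shown sit, caps both values.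

Compound 4 `O=C(Nc1ccc(Sc2nc3ccccc3s2)cc1)c1cccc(Br)c1` differs from compound 3 by hydrogen in place of bromo on an aromatic carbon. Within the data shown here, no measured step removes a bromo group, so none bears directly on this change, and compound 3 itself stands only at a limit. The expected step is therefore a number no higher from compound 3 to compound 4 (the limit leaves the size open), meaning no readable movement. Compound 4 is estimated at 100000 nM, within a range from 40000 nM to 300000 nM, most likely again reported only as a limit.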

Compound 4, half-maximal inhibitory concentration: > 100000 nM
Compound 4: only a limit was reported; the forecaster's own chance of this, stated with the estimate: 85%; the middle value sits exactly at the limit.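

Compound 3 and compound 4 each give only a limit, so the step between them cannot be read: the limit of > 100000 nM in this assay, at which 3 of the 4 values shown sit.

The compounds shown leave open how far going from 3,5-dibromophenyl to 3-bromophenyl moves inhibition in this assay.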